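This account rests on a few compounds, and the source may have more. Where it says the series, first, only, none or still open, it means among the compounds named here.

Measured so far in a functional assay on HepG2 cells (Homo sapiens) for antiproliferative activity, read by MTT assay, with a stated time of 48 h; a lower number here means a stronger inhibitor, a higher number a weaker inhibitor:
compound 1, `CCn1c(C(=O)Nc2ccc(OC(F)(F)F)cc2)ccc1C(CC)(CC)c1ccc(OCCC(O)(CC)CC)c(C)c1`: > 50000 nM
compound 2, `CCn1c(C(=O)N(C)CC(=O)O)ccc1C(CC)(CC)c1ccc(OCCC(O)(CC)CC)c(C)c1`: 5710 nM
compound 3, `CCn1c(C(=O)NC(CC(=O)O)C(=O)OC)ccc1C(CC)(CC)c1ccc(OCCC(O)(CC)CC)c(C)c1`: 10700 nM.

For compound 1 the value is only a limit of this assay, (the limit of > 50000 nM in this assay, at which 1 of the 3 values shown sits); no number is known for it. Compound 4 is `CCn1c(C(=O)NC(C)CO)ccc1C(CC)(CC)c1ccc(OCCC(O)(CC)CC)c(C)c1`. Its change from compound 1: 1-(hydroxymethyl)ethyl in place of 4-(trifluoromethoxy)phenyl on an amide-type nitrogen. Among the compounds with values here, two measured steps bear on this: an at least 8.7-fold lower number from compound 1 to compound 2 (0.94 log units; beyond the scatter) and an at least 4.6-fold lower number from compound 1 to compound 3 (0.66 log units; beyond the scatter), both replacing the 4-(trifluoromethoxy)phenyl on the amide-type nitrogen with a group lacking a ring, and both lowering the number beyond the scatter; between the two replacements, a 1.9-fold higher number from compound 2 to compound 3 (0.27 log units; within the scatter). Compound 4 makes a replacement of the same kind, so a lower number is expected, estimated as an at least 3.3-fold lower number from compound 1 to compound 4 (0.52 log units; beyond the scatter), with the size left open by the limit on compound 1. Compound 4 is therefore expected near 15000 nM, within 4000 nM to 50000 nM.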

Compound 4, half-maximal inhibitory concentration: 43100 nM
Compound 4: middle estimate off by 2.9-fold (0.46 log units), on the low side, within the range that was stated.
By their numbers in this assay, from the lowest: compounds 2 and 3 (each within the scatter of the next); then compound 4. At a limit, above all of these: compound 1.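

With 1-(hydroxymethyl)ethyl in place of 4-(trifluoromethoxy)phenyl, the step reads an at least 1.1-fold lower number from compound 1 to compound 4 (0.06 log units; that floor lies within the scatter), so a group without a ring does not by itself give a clear gain here. The ring-free groups also separate among themselves, so what enters on this nitrogen counts as well as what leaves: a 4.0-fold higher number from compound 3 to compound 4 (0.61 log units; beyond the scatter) and a 7.5-fold higher number from compound 2 to compound 4 (0.88 log units; beyond the scatter). Compound 1 is held only by a limit: the limit of > 50000 nM in this assay, at which 1 of the 4 values shown sits.

As far as these compounds go, whether the gap to compound 4 follows the carboxylic acid of compounds 2 and 3 stays open. From the compounds shown here alone, how an amine or a longer hydroxyalkyl chain on this nitrogen would read is also open.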